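A few compounds are considered here, and "the series" means these few. Any claim that something is new, unique, unknown or untested is made for them only; others in the source may bear on it.

Of the compounds shown here, two sharing one core have been measured so far. Compound 1 `CN(c1ccc2[nH]c(-c3n[nH]c4ccccc34)cc2n1)S(=O)(=O)c1ccccc1` is the parent; in a functional assay on A549 cells (Homo sapiens) for antiproliferative activity, read by MTT assay, with a stated time of 72 h (on this read-out lower numbers stand for stronger inhibition and higher numbers for weaker inhibition), compound 1 gives 14000 nM. Compound 2 `COc1ccc(S(=O)(=O)N(C)c2ccc3[nH]c(-c4n[nH]c5ccccc45)cc3n2)cc1` carries a methoxy in place of hydrogen on an aromatic carbon, and in this assay compound 2 gives 24300 nM, the higher of the two numbers recorded, although the step of a 1.7-fold higher number from compound 1 to compound 2 (0.24 log units; within the scatter) lies within the scatter, so neither compound can be called weaker than the other. Compound 3 `COc1ccc(S(=O)(=O)N(C)c2ccc3[nH]c(-c4n[nH]c5ccccc45)cc3n2)cc1OC` has not yet been measured. It differs from compound 2 by methoxy in place of hydrogen on an aromatic carbon, placed ortho to a methoxy group and meta to a large group; cut one bond further out, the change reads 4-methoxyphenyl to 3,4-dimethoxyphenyl. Going by the values given here, the only measured step that bears on this is the earlier addition of a methoxy to the same ring, which stayed within the scatter. For compound 3 the expected step is therefore small, a 1.2-fold higher number from compound 2 to compound 3 (0.09 log units; within the scatter), leaning slightly toward a higher number but not beyond the scatter. The estimate for compound 3 in this assay is 30000 nM, with a range from 10000 nM to 90000 nM.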

Compound 3, half-maximal inhibitory concentration: > 50000 nM
Compound 3: no number, only a limit (the forecaster's own chance of this, stated with the estimate: 15%); middle value at least 1.6-fold (0.22 log units) from the limit.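

Going by these compounds alone, the second methoxy, placed ortho to a methoxy group and meta to a large group, gives the first step on this ring that lies beyond the scatter in this assay: an at least 2.0-fold higher number from compound 2 to compound 3 (0.31 log units; beyond the scatter). Set against the plain phenyl of the parent, the change to 3,4-dimethoxyphenyl is also beyond the scatter, with an at least 3.5-fold higher number from compound 1 to compound 3 (0.55 log units; beyond the scatter), whereas the single methoxy stayed within it, with a 1.7-fold higher number from compound 1 to compound 2 (0.24 log units; within the scatter). So on this ring one methoxy cannot be told apart from hydrogen in this read-out, while the pair of methoxy groups gives weaker inhibition, and the result for compound 3 is a limit rather than a number: the limit of > 50000 nM in this assay, at which 1 of the 3 values shown sits.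

The compounds shown leave open whether this shift belongs to the methoxy group itself or would also appear with a hydroxyl, a fluorine or an amine on the same carbon. They also leave open whether a methoxy at this place would give the same step without the other methoxy on the ring.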